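The source may report more compounds than this note shows. Statements on the series, on what has been measured and on what is new or still open speak of the compounds shown alone.

Measured so far:
compound 1, `CC(=O)N1CCCN(c2cccc(Nc3nccc(-c4n[nH]c5ccccc45)n3)c2)CC1`: 18 nM
compound 2, `CC(=O)N1CCN(c2ccc(Nc3ncc(C#N)c(-c4n[nH]c5ccccc45)n3)cc2)CC1`: 17 nM

Both numbers come from a functional assay on MV4-11 cells (Homo sapiens) for antiproliferative activity, read by resazurin assay, with a stated time of 72 h; on this read-out higher numbers stand for weaker inhibition of growth and lower numbers for stronger inhibition of growth. Compound 1 gives 18 nM and compound 2 gives 17 nM; the two values lie within the scatter of each other, so nothing separates them here. Compound 1 is the reference for the next step.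

Compound 3, `CC(=O)N1CCCN(c2cccc(Nc3nccc(-c4cnc5n(C)cccc4-5)n3)c2)CC1`, has not yet been measured in this assay. It differs from compound 1 in one place: a group of 10 heavy atoms (8 carbon, 2 nitrogen; one five-membered aromatic ring with 1 hetero atom, one six-membered aromatic ring with 1 hetero atom) in place of a group of 9 heavy atoms (7 carbon, 2 nitrogen; one five-membered aromatic ring with 2 hetero atoms, one six-membered aromatic ring of carbon only), on an aromatic carbon

For the measured compounds named here, no measured pair shows a change of this kind, so there is no step to lean on. The change replaces a group carrying a hydrogen-bond donor with one carrying none, and this kind of exchange is expected to cost some potency. The step from compound 1 to compound 3 in this assay is estimated at a 5.6-fold higher number from compound 1 to compound 3 (0.74 log units; beyond the scatter), a moderate loss beyond the scatter. Compound 3 is therefore expected to give about 100 nM in this assay, with a likely range from 25 nM to 600 nM.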

Compound 3, concentration for 50% growth inhibition: 24 nM
The estimate for compound 3 lay 4.2-fold (0.62 log units) above the measured number; the measured number lies below the stated range.
By their numbers in this assay, from the lowest: compounds 2, 1 and 3 (each within the scatter of the next).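

On an aromatic carbon of a six-membered aromatic ring with 2 nitrogen, replacing 1H-indazol-3-yl with the larger group of compound 3 gives a 1.3-fold higher number from compound 1 to compound 3 (0.12 log units; within the scatter) in this assay. In this one pair, going from a group with 1 hydrogen-bond donor to one with 0 hydrogen-bond donors, and from a six-membered aromatic ring of carbon only to one with 1 hetero atom, leaves the two compounds within the scatter of each other. No supporting measurement bears on why the two groups give such close values.

A single pair cannot show whether this holds for other groups at this position, such as 1-methylindazol-3-yl or plain phenyl. It also leaves open whether the same exchange would behave alike with a nitrile on the core, as in compound 2.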